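Methyl on an aromatic nitrogen: two cores compared

The source may report more compounds than this note shows. Statements on the series, on what has been measured and on what is new or still open speak of the compounds shown alone.

Measured compounds:
compound 1 `COc1ccc(-c2cc3[nH]nc(N)c3c(=O)[nH]2)cc1`: 28% in an assay on isolated protein for inhibition of serine/threonine-protein kinase D2 (Homo sapiens), read by mobility shift assay, tested at 30 uM; on this read-out lower numbers stand for less inhibition and higher numbers for more inhibition at the one concentration tested (going by the name of the read-out)
compound 2 `Cc1cc2[nH]nc(N)c2c(N2CCCCC2)n1`: 14% in this assay
compound 3 `COc1ccc(-c2cc3c(c(N)nn3C)c(=O)[nH]2)cc1`: 36% in this assay

Compound 1 and compound 3 share a core and differ only by methyl in place of hydrogen on an aromatic nitrogen; this step gives a number 8 percentage points higher from compound 1 to compound 3 (within the scatter). Compound 2 carries a different core; the difference between the two cores is not broken down here. Compound 2 gives the lowest of the three numbers, its gap to compound 1 and its gap to compound 3 both lying beyond the scatter.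

Compound 4 `Cc1cc2c(c(N)nn2C)c(N2CCCCC2)n1` is not yet measured and differs from compound 2 by methyl in place of hydrogen on an aromatic nitrogen, the same change as from compound 1 to compound 3, with the place matching word for word; the change occurs in two pairs among the compounds shown. For compound 4 the step of a number 6 percentage points higher from compound 2 to compound 4 (within the scatter) is expected beside the earlier one, because the earlier step gave a number 8 percentage points higher from compound 1 to compound 3 (within the scatter). For the measured compounds named here, no second example of this change on the core of compound 2 is available, so the expectation rests on that single step. Compound 4 is therefore estimated at 20% in this assay, expected between 5% and 38%.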

Compound 4, a percentage reported as inhibition, at one concentration (the size of the read-out at that concentration, not a potency): 16%
For compound 4 the middle estimate is 4 percentage points above the measured one, and the stated range covers the measured number.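

In this assay, methyl in place of hydrogen on an aromatic nitrogen now has a second reading on a different core, with a number 2 percentage points higher from compound 2 to compound 4 (within the scatter) on the core of compound 2. Set beside the reading on the core of compound 1, the two steps cannot be told apart: the same change on two cores in this assay, a number 8 percentage points higher (within the scatter) from compound 1 to compound 3 and a number 2 percentage points higher (within the scatter) from compound 2 to compound 4, 6 percentage points apart, within the scatter of two such steps. For the compounds shown here, neither step lies beyond the scatter, so the two pairs show that this change gives no step that can be resolved on either core at the one concentration tested, but they do not show that it would carry over unchanged to other cores, and with a single pair per core they give no measure of potency.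

Still open, as far as these compounds go, is whether a longer chain such as ethyl, or a carboxylic acid on a short chain, in place of methyl on that aromatic nitrogen would give a step beyond the scatter on either core. From the compounds shown here alone, a third core carrying the methyl change also remains open.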